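From cyclopentyl to methyl: compound 2 and compound 3

A few compounds are considered here, and "the series" means these few. Any claim that something is new, unique, unknown or untested is made for them only; others in the source may bear on it.

In a functional assay (strain AB) with Danio rerio as the target, read by microscopy, with a stated time of 1 h (on this read-out higher numbers stand for an effect only at larger amounts of compound and lower numbers for an effect already at smaller amounts), two members of the series have been measured on a shared core. Compound 1 `CC(C)C[N+]1(C)CCc2c(sc(NC(=O)Nc3ccc(Cl)cc3)c2C(N)=O)C1` gives 380 nM, and compound 2 `C[N+]1(CC2CCCC2)CCc2c(sc(NC(=O)Nc3ccc(Cl)cc3)c2C(N)=O)C1` gives 200 nM. Compound 2 therefore stands level with compound 1 within the scatter, and there is no third value to place it against.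

The next member is compound 3 `CC[N+]1(C)CCc2c(sc(NC(=O)Nc3ccc(Cl)cc3)c2C(N)=O)C1`, not yet measured. Its difference from compound 2 is methyl in place of cyclopentyl on a saturated chain carbon bound to an amine nitrogen in a ring, or cyclopentylmethyl to ethyl when cut one bond further out.

Among the measured compounds shown here, only one measured step bears on this place, and it is a weak guide: a 1.9-fold lower number from compound 1 to compound 2 (0.28 log units; within the scatter). With that step as the sole basis, a modest move toward a higher number is expected in this assay, though the direction remains tentative. The expected step is a 2.1-fold higher number from compound 2 to compound 3 (0.32 log units; beyond the scatter). For compound 3 the estimated value is 420 nM, with an estimated range of 140 nM to 1200 nM.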

Compound 3, half-maximal effective concentration: 1960 nM
The estimate for compound 3 lay 4.7-fold (0.67 log units) below the measured number, and the stated range ends below it.
By their numbers in this assay, from the lowest: compounds 2 and 1 (each within the scatter of the next); then compound 3.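

In this assay, the place on a saturated chain carbon bound to an amine nitrogen in a ring proves responsive to a change of group, which the earlier pair, level within the scatter, could not show. Methyl in place of cyclopentyl gives a 9.8-fold higher number from compound 2 to compound 3 (0.99 log units; beyond the scatter) and methyl in place of isopropyl gives a 5.2-fold higher number from compound 1 to compound 3 (0.71 log units; beyond the scatter) in the same direction, so among these three compounds the choice between cyclopentyl and isopropyl shows no separation, while the change to methyl from either does. No measurement at hand accounts for this rise.

From the compounds shown here alone, three compounds mark out only the ends of this range, so it remains open whether the number changes gradually or abruptly across the groups that would fill it, such as a longer straight chain, and whether it drops further with cyclohexyl or benzyl. Also open, going by these compounds, is how this place responds to a group carrying a hydroxyl, an amine or a carboxylic acid, since all the groups compared here contain carbon only.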